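Thiophen-2-yl for phenyl on a fused pyridine-bearing core

This account rests on a few compounds, and the source may have more. Where it says the series, first, only, none or still open, it means among the compounds named here.

Measured compounds:
compound 1 `Nc1c(C(=O)N/N=C/c2ccccc2)oc2nc(-c3cccs3)cc(C(F)(F)F)c12`: 9900 nM
compound 2 `Cc1ccc(/C=N/NC(=O)c2oc3nc(-c4ccccc4)cc(C(F)(F)F)c3c2N)cc1`: 8900 nM

In a functional assay on HepG2 cells (Homo sapiens) for antiproliferative activity, read by MTT assay (on this read-out lower numbers stand for stronger inhibition and higher numbers for weaker inhibition), compound 2 gives 8900 nM and compound 1 gives 9900 nM. The two numbers lie within the usual scatter of each other, so nothing separates them, and compound 2 cannot be set apart from compound 1 on this evidence.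

Compound 3 `Cc1ccc(/C=N/NC(=O)c2oc3nc(-c4cccs4)cc(C(F)(F)F)c3c2N)cc1` has not yet been measured in this assay. It differs from compound 2 in one place: thiophen-2-yl in place of phenyl on an aromatic carbon. Compound 1 also carries a thiophen-2-yl group, but it differs from compound 3 elsewhere as well, so the pair of compound 1 and compound 2 only shows that two compounds with the two different groups and two different benzylidene parts come out alike.

For the measured compounds named here, no single step between measured compounds tells what this exchange does on its own. With the two values so close, the step from compound 2 to compound 3 is expected to stay within the scatter, a 1.1-fold higher number from compound 2 to compound 3 (0.03 log units; within the scatter). Compound 3 is therefore estimated at 9500 nM in this assay, with a range from 4000 nM to 22000 nM.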

Compound 3, half-maximal inhibitory concentration: 19800 nM
For compound 3 the middle estimate is 2.1-fold (0.32 log units) below the measured one; the range from low to high includes it.
By their numbers in this assay, from the lowest: compounds 2, 1 and 3 (each within the scatter of the next, the first and the last beyond it).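

In this assay, for the compounds shown here, the exchange of phenyl for thiophen-2-yl on the aromatic carbon next to the ring nitrogen gives a 2.2-fold higher number from compound 2 to compound 3 (0.35 log units; beyond the scatter) and is the first step at this position that can be read on its own. The step is modest, but it shows that the two rings are not interchangeable here when the methyl is present, which the earlier pair, differing in two places, could not show. The other step, methyl in place of hydrogen on an aromatic carbon, is a 2.0-fold higher number from compound 1 to compound 3 (0.30 log units; within the scatter) and so gives no sign that the methyl matters when thiophen-2-yl is present. No measurement is at hand that would explain either step.

On these data alone, the exchange of phenyl for thiophen-2-yl is read in a single pair, so whether it gives a similar step without the methyl remains open. Also open, as far as these compounds go, is how a morpholine, a pyridin-3-yl group or a simple amine on this same carbon would compare with phenyl and thiophen-2-yl.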